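Anilide variation in a sulfone series

A few compounds are considered here, and "the series" means these few. Any claim that something is new, unique, unknown or untested is made for them only; others in the source may bear on it.

Compound 1 `COc1ccc(CS(=O)(=O)/C=C/c2c(OC)cccc2OC)cc1N`: 50 nM
Compound 2 `COc1ccc(CS(=O)(=O)CC(=O)Nc2c(C)cc(C)cc2C)cc1[N+](=O)[O-]`: > 30000 nM
Compound 3 `COc1ccc(CS(=O)(=O)CC(=O)Nc2c(C)cc(C)cc2C)cc1N`: > 30000 nM

In a functional assay on T47D cells (Homo sapiens) for cytotoxicity, read by MTT assay, with a stated time of 72 h (a higher number here means a weaker inhibitor of growth, a lower number a stronger inhibitor of growth), compound 1 gives 50 nM. For compound 2 only a limit of the assay is recorded, > 30000 nM. For compound 3 the same limit is recorded, > 30000 nM. Among the compounds with values here, the one measured step between neighbours, a step that the two limits leave unreadable from compound 2 to compound 3, therefore cannot be read for size or direction. Within the data shown here, compound 2 thus stands at the assay limit, with no number of its own, and the limit of > 30000 nM in this assay, at which 2 of the 3 values shown sit, is the only evidence that frames it.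

Compound 4 `COc1ccc(CS(=O)(=O)CC(=O)Nc2ccccc2)cc1[N+](=O)[O-]` differs from compound 2 in one place: phenyl in place of 2,4,6-trimethylphenyl on an amide-type nitrogen. Among the measured compounds shown here, no measured pair shows this change, and the only step that starts from compound 2 is unreadable, so nothing in the data sets a size for the change in this assay. The expectation for compound 4 is that it stays near the limit where compound 2 sits, with wide uncertainty; the expected step of a number no higher from compound 2 to compound 4 (the limit leaves the size open) is accordingly near zero. Compound 4 is therefore estimated at 30000 nM, with a range from 3000 nM to 100000 nM.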

Compound 4, concentration for 50% growth inhibition: > 30000 nM
Compound 4 was reported as a limit; the forecaster's own chance of this, stated with the estimate: 60%; the middle value sits exactly at the limit.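

In this assay compound 4 records only the limit > 30000 nM and no number. No step can be read between compound 2 and compound 4 because both stand at the limit: the limit of > 30000 nM in this assay, at which 3 of the 4 values shown sit. On these data alone, whether phenyl in place of 2,4,6-trimethylphenyl on an amide-type nitrogen changes growth inhibition at all remains open.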